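This account rests on a few compounds, and the source may have more. Where it says the series, first, only, none or still open, it means among the compounds named here.

Among the measured compounds shown here, compound 2 `Cc1nc(S(C)(=O)=O)ccc1Oc1ncnc(OC2CCN(C(=O)O[C@H](C)CF)CC2)c1F` stands lowest of the two numbers measured so far: in a functional assay on isolated protein for inhibition of Glucose-dependent insulinotropic receptor (Rattus norvegicus), read by HTRF and cAMP accumulation (a higher number here means a larger maximal response, a lower number a smaller maximal response), compound 2 gives 79%, whereas compound 1 `Cc1nc(S(C)(=O)=O)ccc1Oc1ncnc(OC2CCN(C(=O)OC(C)(C)C#N)CC2)c1F` gives 97%. For the measured compounds named here, the single measured step, a number 18 percentage points lower from compound 1 to compound 2 (beyond the scatter), arose from swapping one group for another on an oxygen next to a carbonyl group, so it touches the same part of the shared core as the change now considered. Compound 3 `Cc1nc(S(C)(=O)=O)ccc1Oc1ncnc(OC2CCN(C(=O)SC3CC3)CC2)c1F` differs from compound 2 by a group of 4 heavy atoms (3 carbon, 1 sulfur; one three-membered non-aromatic ring of carbon only) in place of a group of 5 heavy atoms (3 carbon, 1 oxygen, 1 fluorine; no ring), on a carbonyl carbon. Going by the values given here, only that one step is available to judge from, and it was modest; a change of comparable size in either direction, or none beyond the scatter, seems plausible, with the two measured values setting the likely band. Compound 3 is therefore expected to give about 86%, between 66% and 100%. This estimate corresponds to a step of a number 7 percentage points higher from compound 2 to compound 3 (within the scatter).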

Compound 3, largest response reached (reported as efficacy), in percent of the reference or control that the assay uses: 80%
Estimate against measurement, compound 3: 6 percentage points above; measured number inside the range.
By their numbers in this assay, from the lowest: compounds 2 and 3 (each within the scatter of the next); then compound 1.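

The step, a number 1 percentage points higher from compound 2 to compound 3 (within the scatter), shows that in this assay a sulfur-linked three-membered carbon ring on this carbonyl carbon reads the same as the open-chain, fluorine-bearing group, even though the two groups share neither a linking atom nor a ring. The step of a number 17 percentage points lower from compound 1 to compound 3 (beyond the scatter) shows a second replacement of the 1-cyano-1-methylethyl group that ends up beyond the scatter from compound 1, so the gap seen earlier is not tied to one particular replacement. Nothing measured here explains these numbers.

From the compounds shown here alone, each step exchanges several atoms at once, so it stays open whether the sulfur or the ring in compound 3, or the nitrile in compound 1, accounts for any of this. Going by these compounds, how a tert-butyl group or an amine would read on this carbonyl carbon also remains open.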